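Pyrrolidinylmethyl side chain on the dichloro urea-amide core

A few compounds are considered here, and "the series" means these few. Any claim that something is new, unique, unknown or untested is made for them only; others in the source may bear on it.

Within the data shown here, compound 3 `Cc1cc(C(=O)Nc2ccc(Cl)cc2)ccc1N(CC(=O)N1CCOCC1)C(=O)Nc1ccc(Cl)cc1` carries the highest number of the three measured members in an ADME assay on microsomes from liver (Homo sapiens) for metabolic stability (on this read-out lower numbers stand for a shorter-lived compound and higher numbers for a longer-lived compound), where compound 3 gives 0.532 h. Compound 1 `Cc1cc(C(=O)Nc2ccc(F)cn2)ccc1N(CCN1CCCC1)C(=O)Nc1ccc(Cl)cc1` gives 0.458 h, which sits within the scatter of compound 3. Among the measured compounds shown here, compound 2 `Cc1cc(C(=O)Nc2ccc(Cl)cc2)ccc1N(CCN1CCCC1=O)C(=O)Nc1ccc(Cl)cc1` gives 0.158 h, and the one step that has been measured in one place, a 3.4-fold higher number from compound 2 to compound 3 (0.53 log units; beyond the scatter), is the only one beyond the scatter in this set.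

Compound 4 `Cc1cc(C(=O)Nc2ccc(Cl)cc2)ccc1N(CCN1CCCC1)C(=O)Nc1ccc(Cl)cc1` differs from compound 3 by (pyrrolidin-1-yl)methyl in place of (morpholin-4-yl)carbonyl on a saturated chain carbon bound to an amide-type nitrogen. For the measured compounds named here, no measured step covers this exchange: the step from compound 2 to compound 3 concerns a different pair of groups, and compound 1, which shares the (pyrrolidin-1-yl)methyl side chain with compound 4, differs from it elsewhere, so its value can only be read as a hint. That hint, compound 1 at 0.458 h, points to a number close to compound 3. The expected step is therefore a 1.3-fold lower number from compound 3 to compound 4 (0.10 log units; within the scatter), within the scatter. Compound 4 is estimated at 0.42 h, with a range from 0.2 h to 0.9 h.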

Compound 4, half-life: 3.28 h
Beside the measured number, compound 4's estimate is 7.8-fold (0.89 log units) below it, outside the stated range (above it).
By their numbers in this assay, from the lowest: compound 2; then compounds 1 and 3 (each within the scatter of the next); then compound 4.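

In this assay, among these compounds, the group on a saturated chain carbon bound to an amide-type nitrogen proves far more influential than the earlier compounds showed, with (pyrrolidin-1-yl)methyl in place of (morpholin-4-yl)carbonyl giving a 6.2-fold higher number from compound 3 to compound 4 (0.79 log units; beyond the scatter) and the loss of the ring carbonyl alone giving a 21-fold higher number from compound 2 to compound 4 (1.32 log units; beyond the scatter) in the largest step of the set. The group on the amide-type nitrogen also matters with the 2-(pyrrolidin-1-yl)ethyl chain held constant, since 4-chlorophenyl in place of 5-fluoropyridin-2-yl gives a 7.2-fold higher number from compound 1 to compound 4 (0.86 log units; beyond the scatter) in this series. No evidence on the origin of these steps is available.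

On these data alone, whether the carbonyl or the ring type carries the step to compound 4 remains open, and (pyrrolidin-1-yl)carbonyl or 2-(morpholin-4-yl)ethyl at this place would separate the two. Also open, as far as these compounds go, is whether a piperidine ring or an open-chain dimethylamino group would keep the number of compound 4.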